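The source may hold more compounds than are shown below. What is called first, only, known or untested is meant among the compounds shown, and "the series" means these compounds.

Measured compounds:
compound 1, `COC(=O)[C@@]1(C)CCC=C2[C@@H]1CC[C@@H](C)[C@]2(C)Cc1c[nH]c2c(C)cccc12`, 11000 nM;
compound 2, `COC(=O)[C@@]1(C)CCC=C2[C@@H]1CC[C@@H](C)[C@]2(C)Cc1c[nH]c2c(Br)cccc12`, 22000 nM;
compound 3, `COC(=O)[C@@]1(C)CC[C@@H]2C3=C1CC[C@@H](C)[C@]3(C)Cc1c2[nH]c2c(C)cccc12`, 16000 nM.

All three were tested in a functional assay on A549 cells (Homo sapiens) for inhibition, read by sulforhodamine B assay, with a stated time of 48 h; a lower number here means a stronger inhibitor of growth, a higher number a weaker inhibitor of growth. Compound 1 gives 11000 nM, compound 2 gives 22000 nM, and compound 3 gives 16000 nM. The difference between the core of compound 1 and the core of compound 3 is not broken down here. Compound 2 differs from compound 1 in one place only: bromo in place of methyl on an aromatic carbon. That change gave a 2.0-fold higher number from compound 1 to compound 2 (0.30 log units; within the scatter).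

Compound 4, `COC(=O)[C@@]1(C)CC[C@@H]2C3=C1CC[C@@H](C)[C@]3(C)Cc1c2[nH]c2c(Br)cccc12`, has not yet been measured. It differs from compound 3 in the same kind of way: bromo in place of methyl on an aromatic carbon. The place lines are not identical, since in compound 1 the aromatic ring is part of a fused or bridged system of two rings, while in compound 3 it is part of a fused or bridged system of five rings, so this is the same kind of change rather than the same change.

Going by the values given here, the only guide is the step from compound 1 to compound 2, which stayed within the scatter. The step from compound 3 to compound 4 is therefore expected to be a 1.8-fold higher number from compound 3 to compound 4 (0.24 log units; within the scatter), small because a 2.0-fold higher number from compound 1 to compound 2 (0.30 log units; within the scatter). On that basis compound 4 is expected to give about 28000 nM in this assay, most likely between 12000 nM and 65000 nM.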

Compound 4, concentration for 50% growth inhibition: 35000 nM
For compound 4 the middle estimate is 1.3-fold (0.10 log units) below the measured one, within the range that was stated.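

In this assay, putting bromo in place of methyl on an aromatic carbon gave a 2.2-fold higher number from compound 3 to compound 4 (0.34 log units; beyond the scatter), a modest step that makes compound 4 the weaker growth inhibitor of this pair. Set beside the earlier step on the other core, the change carries over at much the same size: the same change on two cores in this assay, a 2.0-fold higher number (0.30 log units; within the scatter) from compound 1 to compound 2 and a 2.2-fold higher number (0.34 log units; beyond the scatter) from compound 3 to compound 4, 1.1-fold (0.04 log units) apart, within the scatter of two such steps

Going by these compounds alone, this rests on only two pairs of compounds, tested on one cell line at one stated time, so it does not show that the same would hold on a third core, and it says nothing about why the numbers move; moreover, one of the two steps stays within the scatter, so only the step on the core of compound 3 stands as a change in its own right.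

All the compounds shown carry either methyl or bromo at this aromatic carbon, which leaves open what a chlorine, a methoxy group or an amine would do there. They also all keep the same methyl ester, so the effect of a carboxylic acid or an amide in its place remains an open question on both cores.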